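The source may report more compounds than this note shows. Statements on the series, on what has been measured and on what is new or still open speak of the compounds shown alone.

Working notes on the series. For the measured compounds named here, in a functional assay on SH-SY5Y cells (Homo sapiens) for cytotoxicity, read by MTT assay, with a stated time of 72 h (on this read-out lower numbers stand for stronger inhibition and higher numbers for weaker inhibition), compound 1 (`O=C1c2c[n+]([O-])c3ccccc3c2C(=O)c2c1c1ccccc1n2Cc1cn([C@@H]2C[C@H](O)[C@@H](CO)O2)nn1`) gives 150 nM and compound 2 (`CC1(C)OC[C@H](Cn2cc(Cn3c4c(c5ccccc53)C(=O)c3c[n+]([O-])c5ccccc5c3C4=O)nn2)O1`) gives 820 nM as the higher of the two numbers so far. Going by the values given here, the one measured step is a 5.5-fold higher number from compound 1 to compound 2 (0.74 log units; beyond the scatter) with (2,2-dimethyl-1,3-dioxolan-4-yl)methyl in place of 4-hydroxy-5-(hydroxymethyl)oxolan-2-yl on an aromatic nitrogen. Compound 3 (`O=C1c2c[n+]([O-])c3ccccc3c2C(=O)c2c1c1ccccc1n2Cc1cn([C@@H]2O[C@H](CO)[C@@H](O)[C@H](O)[C@H]2O)nn1`) brings the change 3,4,5-trihydroxy-6-(hydroxymethyl)oxan-2-yl in place of (2,2-dimethyl-1,3-dioxolan-4-yl)methyl on an aromatic nitrogen and so has 3,4,5-trihydroxy-6-(hydroxymethyl)oxan-2-yl in place of (2,2-dimethyl-1,3-dioxolan-4-yl)methyl on an aromatic nitrogen. The entering group resembles the group of compound 1 in carrying hydroxy groups on a non-aromatic ring, so part of a 5.5-fold higher number from compound 1 to compound 2 (0.74 log units; beyond the scatter) is expected to be reversed. Among the compounds with values here, that single step is the only guide. In this assay a modest move to a lower number is therefore expected, with a 2.7-fold lower number from compound 2 to compound 3 (0.44 log units; beyond the scatter) as the estimated step. For compound 3 the estimated value is 300 nM with an expected range from 90 nM to 1000 nM for now.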

Compound 3, half-maximal inhibitory concentration: 880 nM
Beside the measured number, compound 3's estimate is 2.9-fold (0.47 log units) below it, within the range that was stated.
By their numbers in this assay, from the lowest: compound 1; then compounds 2 and 3 (each within the scatter of the next).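

In this assay, carrying hydroxy groups on a non-aromatic ring is not enough to match compound 1: the step to 3,4,5-trihydroxy-6-(hydroxymethyl)oxan-2-yl is a 1.1-fold higher number from compound 2 to compound 3 (0.03 log units; within the scatter), so a group with 4 hydrogen-bond donors and one with 0 sit within the scatter of each other at this aromatic nitrogen. Against 4-hydroxy-5-(hydroxymethyl)oxolan-2-yl, the same change gives a 5.9-fold higher number from compound 1 to compound 3 (0.77 log units; beyond the scatter), which leaves compound 1 alone among the three at the low end. Nothing at hand offers a reason for this separation.

Still open, as far as these compounds go, is whether the separation of compound 1 follows the ring size, the number of hydroxy groups or the stereocentres of its group. The compounds shown also leave open how a simple open chain such as 2-hydroxyethyl, or an amine or a carboxylic acid, would behave on this nitrogen.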